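Chain shortening from compound 2 to compound 4

The source may hold more compounds than are shown below. What is called first, only, known or untested is meant among the compounds shown, and "the series" means these compounds.

Within the data shown here, compound 2 `Cn1nc(CCO[Si](c2ccccc2)(c2ccccc2)C(C)(C)C)ccc1=O` is the only member of the set with a number in a functional assay on aorta (Rattus norvegicus) (on this read-out lower numbers stand for stronger inhibition and higher numbers for weaker inhibition), where compound 2 gives 47000 nM. Compound 1 `CC(C)(C)[Si](OCCc1ccc(=O)n(Cc2ccccc2)n1)(c1ccccc1)c1ccccc1` stops at a limit of this assay, > 100000 nM. Compound 3 `Cn1nc(CCCO[Si](c2ccccc2)(c2ccccc2)C(C)(C)C)ccc1=O` likewise stops at a limit in this assay, > 100000 nM. Two of the three results thus sit at the limit of > 100000 nM in this assay, at which 2 of the 3 values shown sit. The measured changes are an at least 2.1-fold lower number from compound 1 to compound 2 (0.32 log units; beyond the scatter) and an at least 2.1-fold higher number from compound 2 to compound 3 (0.32 log units; beyond the scatter). Compound 4 `Cn1nc(CO[Si](c2ccccc2)(c2ccccc2)C(C)(C)C)ccc1=O` is not yet measured; it differs from compound 2 as follows: a group of 8 heavy atoms (5 carbon, 2 nitrogen, 1 oxygen; one six-membered aromatic ring with 2 hetero atoms) in place of a group of 9 heavy atoms (6 carbon, 2 nitrogen, 1 oxygen; one six-membered aromatic ring with 2 hetero atoms), on a saturated chain carbon bound to an oxygen on an unsaturated carbon. The step from compound 2 to compound 3 is the one that touches the same chain, in the opposite sense; the step from compound 1 to compound 2 concerns another part of the molecule. One step on this chain pointing to weaker inhibition on lengthening does not fix the direction for shortening, so a number near compound 2 is expected, with wide spread and a real chance of only a limit. For compound 4 the expected value in this assay is 60000 nM, estimated to lie between 20000 nM and 150000 nM. The estimate implies a 1.3-fold higher number from compound 2 to compound 4 (0.11 log units; within the scatter).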

Compound 4, half-maximal inhibitory concentration: 58400 nM
The estimate for compound 4 lay 1.0-fold (0.01 log units) above the measured number, and the stated range covers the measured number.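

Shortening the chain gives a 1.2-fold higher number from compound 2 to compound 4 (0.09 log units; within the scatter) in this assay, so compound 2 and compound 4 read alike at this saturated chain carbon. The only earlier step on this chain was lengthening, an at least 2.1-fold higher number from compound 2 to compound 3 (0.32 log units; beyond the scatter), so among these three chain lengths, only the longest chain stands apart from compound 2. Compound 3 gives only a limit of the assay, > 100000 nM, and this caps what can be read from the series: the limit of > 100000 nM in this assay, at which 2 of the 4 values shown sit.

Open is how the series reads with a free alcohol or an amine in place of the tert-butyldiphenylsilyl group on the chain, since all compounds shown carry that group. From the compounds shown here alone, how far compound 1 and compound 3 lie past the limit also stays unknown.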